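Nitro substitution and tolerated concentration on azobenzene cores

This account rests on a few compounds, and the source may have more. Where it says the series, first, only, none or still open, it means among the compounds named here.

Three compounds were measured in an ADME assay on MT4 cells (Homo sapiens) for cytotoxicity, read by MTT assay, with a stated time of 96 h; a higher number here means that more compound is tolerated, a lower number that less compound is tolerated. Compound 1 `CN(/N=N/c1ccccc1)c1ccccc1` gives 55000 nM in this assay. Compound 2 `CN(C)CCCNc1ccc(/N=N/c2ccccc2)cc1` gives 17000 nM in this assay, the lowest of the two numbers shown, and compound 1 sits a higher number away, beyond the scatter. The difference between the core of compound 1 and the core of compound 2 is not broken down here. Compound 3 `CN(/N=N/c1cccc([N+](=O)[O-])c1)c1ccccc1` gives > 100000 nM in this assay, which is a limit of the assay and not a number. That is the limit of > 100000 nM in this assay, at which 1 of the 3 values shown sits. The change from compound 1 to compound 3 is nitro in place of hydrogen on an aromatic carbon, and it gave an at least 1.8-fold higher number from compound 1 to compound 3 (0.25 log units; that floor lies within the scatter).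

Compound 4 `CN(C)CCCNc1ccc(/N=N/c2ccc([N+](=O)[O-])cc2)cc1` has not yet been measured in this assay. It differs from compound 2 by nitro in place of hydrogen on an aromatic carbon. This is the same kind of change as that from compound 1 to compound 3, but not the same change: in compound 3 the nitro sits meta to a large group, while in compound 4 it sits para to a large group. Compound 4 is expected to show a step of a 1.5-fold higher number from compound 2 to compound 4 (0.17 log units; within the scatter), resting on the value of compound 2, 17000 nM, and on the direction of the measured step of an at least 1.8-fold higher number from compound 1 to compound 3 (0.25 log units; that floor lies within the scatter). Compound 4 is therefore estimated at 25000 nM in this assay, with a range of 10000 nM to 70000 nM expected.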

Compound 4, half-maximal cytotoxic concentration: 19000 nM
Compound 4: middle estimate off by 1.3-fold (0.12 log units), on the high side, within the range that was stated.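

On the core of compound 2, nitro in place of hydrogen on an aromatic carbon, para to a large group, gave a 1.1-fold higher number from compound 2 to compound 4 (0.05 log units; within the scatter) in this assay, which leaves compound 2 and compound 4 within the scatter of each other. Set beside the same kind of change on the core of compound 1, this second step does not settle whether the change behaves alike on the two cores: the same change on two cores in this assay, an at least 1.8-fold higher number (0.25 log units; that floor lies within the scatter) from compound 1 to compound 3 and a 1.1-fold higher number (0.05 log units; within the scatter) from compound 2 to compound 4; the limit leaves it open whether they differ Neither printed figure lies beyond the scatter, but this does not show that the change carries over unaltered from one core to the other, and the nitro does not stand in the same place on the two cores.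

The compounds shown leave open how an amine or a carboxylic acid in place of the nitro would read on either core, and what a longer chain in place of the side chain of compound 2 and compound 4 would do. How far compound 3 really lies from the other compounds also stays open, as its value is a limit and not a number: the limit of > 100000 nM in this assay, at which 1 of the 4 values shown sits.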